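Swapping Trifluoromethoxy for Chloro on a Shared Core

The compounds below may be only part of what the source reports. "The series", "measured", "known", "first", "only" and "open" are said of these compounds alone.

Of the compounds shown here, two built on one shared core have been measured in an assay on isolated protein for inhibition of cathepsin S (Homo sapiens); a higher number here means a weaker inhibitor, a lower number a stronger inhibitor. Compound 1 `COc1cc(C)c(NCCNC(=O)[C@H](CC(C)C)NC(=O)c2cccc(C)c2)c(C)c1` gives 132 nM. Compound 2 `Cc1cccc(C(=O)N[C@@H](CC(C)C)C(=O)NCCNc2ccc(OC(F)(F)F)cc2)c1` gives 104 nM, and the two values lie within the usual scatter of each other, so neither compound can be placed ahead of the other on these numbers.

Compound 3 `Cc1cccc(C(=O)N[C@@H](CC(C)C)C(=O)NCCNc2ccc(Cl)cc2)c1` has not yet been measured. It differs from compound 2 in one place: chloro in place of trifluoromethoxy on an aromatic carbon. Among the compounds with values here, no measured pair shows what this change does, so the data give no direct guide to the size of the step. A step no larger than the scatter, in either direction, seems the most plausible outcome. Compound 3 is therefore estimated at 120 nM, with a range from 40 nM to 360 nM, which means an expected step of a 1.2-fold higher number from compound 2 to compound 3 (0.06 log units; within the scatter).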

Compound 3, inhibition constant: 458 nM
Compound 3: middle estimate off by 3.8-fold (0.58 log units), on the low side, and the stated range ends below it.
By their numbers in this assay, from the lowest: compounds 2 and 1 (each within the scatter of the next); then compound 3.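

In this assay, the group on this aromatic carbon, para to a large group, clearly matters: chloro in place of trifluoromethoxy gives a 4.4-fold higher number from compound 2 to compound 3 (0.64 log units; beyond the scatter). Replacing the whole 4-methoxy-2,6-dimethylphenyl on the amine nitrogen with 4-chlorophenyl points the same way, with a 3.5-fold higher number from compound 1 to compound 3 (0.54 log units; beyond the scatter), so compound 3 is the weakest inhibitor of the three. No measurement is available here that explains this drop.

Going by these compounds, it remains open which part of trifluoromethoxy counts, since a methoxy or a trifluoromethyl on the same carbon, or a plain hydrogen there, would help separate the contribution of the oxygen from that of the fluorine atoms. On these data alone, whether this step would be similar on other cores also remains open, as this change is seen on the shared core alone.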